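The source may report more compounds than this note shows. Statements on the series, on what has been measured and on what is new or still open speak of the compounds shown alone.

Working notes on a small set of sulfonamide-bearing compounds measured in a physicochemical assay for lipophilicity; on this read-out lower numbers stand for lower lipophilicity and higher numbers for higher lipophilicity. Compound 1 `CN1C=CN(C2NC(C(Cl)(Cl)Cl)=CN2c2ccc(S(N)(=O)=O)cc2)C=C1` gives 2.85, the highest of the three numbers in hand. Compound 3 `CN1C=CC(C2OC(C(F)(F)F)=CN2c2ccc(S(N)(=O)=O)cc2)C=C1` gives 2.05, the nearest number, lying below compound 1 beyond the scatter, and compound 2 `CC1=CN(c2ccc(S(N)(=O)=O)cc2)C(N2C=CN(C)C=C2)S1` gives 1.75, the furthest number, also below compound 1 beyond the scatter. The next compound to be run is compound 4 `CC1=CN(c2ccc(S(N)(=O)=O)cc2)C(N2C=CN(C)C=C2)N1`, which differs from compound 1 in one place: methyl in place of trichloromethyl on a double-bonded ring carbon. With methyl in place of trichloromethyl, the read-out for compound 4 is expected to fall rather than rise, by a step well beyond the scatter, estimated as a number 1.25 log units lower from compound 1 to compound 4 (beyond the scatter). On that basis compound 4 is expected to give about 1.6 in this assay, in a range from 1 to 2.2.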

Compound 4, partition coefficient: 1.44
Compound 4: middle estimate off by 0.16 log units, on the high side, within the range that was stated.
By their numbers in this assay, from the lowest: compound 4; then compounds 2 and 3 (each within the scatter of the next); then compound 1.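

In this assay, for the compounds shown here, methyl in place of trichloromethyl on the double-bonded ring carbon gives a number 1.41 log units lower from compound 1 to compound 4 (beyond the scatter), the first step read at a single place. Going by these compounds alone, compounds 2 and 3 differ from compound 1 in more than one place, so only this pair ties a large change to this position and this exchange. Nothing at hand accounts for the size of the step. Open, from the compounds shown here alone, is where an amine, a carboxylic acid or a longer chain on this carbon would fall in this assay. Also open, going by these compounds, is whether the same exchange gives a similar step on another core.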